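The source may report more compounds than this note shows. Statements on the series, on what has been measured and on what is new or still open speak of the compounds shown alone.

In an in vitro ADME assay on microsomes from liver (Homo sapiens) for metabolic stability (a higher number here means that the compound lasts longer, a lower number that the compound disappears faster), compound 2, `COc1ccc(-c2cc(-c3ccc(C(F)(F)F)cc3)cnc2N)cn1`, gives 4.75 h. Among the measured compounds shown here, compound 1, `CNS(=O)(=O)c1ccc(-c2cnc(N)c(-c3ccc(OC)nc3)c2)cc1`, is the only other compound measured, and in this assay compound 1 gives 3.02 h; the two numbers lie within the scatter of each other, so neither can be set above the other. For the measured compounds named here, the one measured step, a 1.6-fold higher number from compound 1 to compound 2 (0.20 log units; within the scatter), is the only guide available for the next change, which is 1H-pyrazol-1-yl in place of trifluoromethyl on an aromatic carbon and leads to compound 3, `COc1ccc(-c2cc(-c3ccc(-n4cccn4)cc3)cnc2N)cn1`. That earlier exchange at the same place passed without a shift beyond the scatter, and the new exchange again touches only the group on that aromatic carbon while the rest of the shared core stays as it is. Compound 3 is therefore expected to show no step beyond the scatter, with the estimated change being a 1.4-fold lower number from compound 2 to compound 3 (0.13 log units; within the scatter). In this assay compound 3 is estimated at 3.5 h, with a range expected from 1.5 h to 8 h.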

Compound 3, half-life: 3.38 h
For compound 3 the middle estimate is 1.0-fold (0.02 log units) above the measured one, within the range that was stated.
By their numbers in this assay, from the lowest: compounds 1, 3 and 2 (each within the scatter of the next).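

In this assay, the exchange of trifluoromethyl for 1H-pyrazol-1-yl gives a 1.4-fold lower number from compound 2 to compound 3 (0.15 log units; within the scatter), and the exchange of methylsulfamoyl for the same group gives a 1.1-fold higher number from compound 1 to compound 3 (0.05 log units; within the scatter), so all three groups at this place lie within the scatter of one another. The earlier pair held no ring at this aromatic carbon, whereas compound 3 shows that a five-membered aromatic ring with 2 hetero atoms can stand here, para to a large group, without a step beyond the scatter; the half-life of the series has so far shown no measurable response to the group at this position, across three quite different groups. Nothing measured here bears on what lies behind these numbers.

Among the compounds shown here, it remains open whether an amine, a carboxylic acid or a longer chain on this same carbon would bring the first step beyond the scatter. Going by these compounds, it also remains open whether a change elsewhere on the shared core would move the half-life, since all three compounds differ only at this one place.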